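Swapping the aryl group on the piperazine of compound 3

The source may report more compounds than this note shows. Statements on the series, on what has been measured and on what is new or still open speak of the compounds shown alone.

Of the compounds shown here, three of a shared core have been measured in a functional assay on MCF7 cells (Homo sapiens) for inhibition, read by MTT assay, with a stated time of 72 h; on this read-out higher numbers stand for weaker inhibition and lower numbers for stronger inhibition. Compound 1 `O=C1Nc2ccccc2/C1=N/NC(=S)N1CCN(c2ccccc2)CC1` gives 24900 nM, and compound 2 `COc1ccc2c(c1)/C(=N/NC(=S)N1CCN(c3ccccc3)CC1)C(=O)N2` gives 14400 nM, with the step of a 1.7-fold lower number from compound 1 to compound 2 (0.24 log units; within the scatter) lying within the scatter. Compound 3 `Cc1ccc(N2CCN(C(=S)N/N=C3\C(=O)Nc4ccc(Cl)cc43)CC2)cc1` gives 17100 nM, a number within the scatter of both compound 1 and compound 2. Compound 4 `O=C1Nc2ccc(Cl)cc2/C1=N/NC(=S)N1CCN(c2ccccc2F)CC1` differs from compound 3 by 2-fluorophenyl in place of 4-methylphenyl on an amine nitrogen in a ring. Among the measured compounds shown here, no measured step touches this ring on the amine nitrogen: the only step known, a 1.7-fold lower number from compound 1 to compound 2 (0.24 log units; within the scatter), concerns a methoxy on an aromatic carbon and was itself within the scatter. With no guide, compound 4 is expected to show a 1.0-fold lower number from compound 3 to compound 4 (0.00 log units; within the scatter), nothing beyond scatter. Compound 4 is therefore estimated at 17000 nM, within a range from 7000 nM to 42000 nM.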

Compound 4, half-maximal inhibitory concentration: 15200 nM
Compound 4: the middle estimate sits 1.1-fold (0.05 log units) above what was measured; low and high end bracket the measured number.
By their numbers in this assay, from the lowest: compounds 2, 4, 3 and 1 (each within the scatter of the next).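

In this assay, among the compounds shown here, the only measured step at this position, a 1.1-fold lower number from compound 3 to compound 4 (0.05 log units; within the scatter), shows that 2-fluorophenyl in place of 4-methylphenyl on an amine nitrogen in a ring leaves the number within the scatter. This one exchange of aromatic groups therefore does not separate the two compounds. No measurement available here bears on this result. Still open, on these data alone, is whether a phenyl ring carrying a carboxylic acid or an amine would move the number beyond the scatter. The same question stands for a non-aromatic group on this nitrogen, such as a longer alkyl chain.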